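Swapping the Ether Tail: Thiazole Ethyl Replaces Fluorophenyl Oxolane

A few compounds are considered here, and "the series" means these few. Any claim that something is new, unique, unknown or untested is made for them only; others in the source may bear on it.

Compound 3 `Cc1nc(C)c([C@H](OC(C)(C)C)C(=O)O)c(N2CCC(C)(C)CC2)c1-c1ccc(OC2COCC2c2ccc(F)cc2)cc1` shares its core with compound 1 `COc1cccc(CCOc2ccc(-c3c(C)nc(C)c([C@H](OC(C)(C)C)C(=O)O)c3N3CCC(C)(C)CC3)cc2)c1` and compound 2 `Cc1nc(C)c([C@H](OC(C)(C)C)C(=O)O)c(N2CCC(C)(C)CC2)c1-c1ccc(CCCc2ccc(F)cc2)cc1`. In an ADME assay on microsomes from liver (Rattus norvegicus) for metabolic stability, read by LC-MS, tested at 0.5 uM (a lower number here means that the compound disappears faster, a higher number that the compound lasts longer), compound 3 gives > 2 h, which is a limit of the assay rather than a number. Compound 1 also reaches a limit there, at > 2 h. Compound 2 likewise sits at the limit of > 2 h. The step that the two limits leave unreadable from compound 1 to compound 2 and the step that the two limits leave unreadable from compound 1 to compound 3 cannot be given a size because of the limit of > 2 h in this assay, at which 3 of the 3 values shown sit. Compound 4 `Cc1ncsc1CCOc1ccc(-c2c(C)nc(C)c([C@H](OC(C)(C)C)C(=O)O)c2N2CCC(C)(C)CC2)cc1` differs from compound 3 in one place: 2-(4-methyl-1,3-thiazol-5-yl)ethyl in place of 4-(4-fluorophenyl)oxolan-3-yl on an oxygen on an aromatic ring. Among the compounds with values here, no measured step covers this particular exchange, and the two steps that were measured both end at the limit, so they show neither direction nor size. The expectation for compound 4 therefore rests only on compound 3 standing at its limit, and the estimated step of a number no higher from compound 3 to compound 4 (the limit leaves the size open) is taken as none beyond the scatter. Compound 4 is expected to give about 2 h in this assay, with a range from 0.8 h to 4 h.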

Compound 4, half-life: > 2 h
Compound 4: only a limit was reported; the forecaster's own chance of this, stated with the estimate: 55%; the middle value lies on the limit itself.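

The steps from compound 1, compound 2 and compound 3 to compound 4 cannot be read, because all four compounds stand at a limit rather than a number: the limit of > 2 h in this assay, at which 4 of the 4 values shown sit.

The compounds shown leave open how long each one actually lasts and whether the exchanged groups make any difference.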